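This account rests on a few compounds, and the source may have more. Where it says the series, first, only, none or still open, it means among the compounds named here.

Measured so far in a functional assay (strain AB) with Danio rerio as the target, read by microscopy, with a stated time of 1 h (on this read-out higher numbers stand for an effect only at larger amounts of compound and lower numbers for an effect already at smaller amounts), are these compounds:

- compound 1 `CN1CCc2c(sc(NC(=O)Nc3ccc(Cl)cc3)c2C(N)=O)C1` gives 4700 nM
- compound 2 `NC(=O)c1c(NC(=O)Nc2ccc(Cl)cc2)sc2c1CCN(CC1CCCCC1)C2` gives 1890 nM
- compound 3 `NC(=O)c1c(NC(=O)Nc2ccc(Cl)cc2)sc2c1CCN(CC1CCC1)C2` gives 1360 nM

Compound 3 stands at the low end of these numbers, but it shares that end with compound 2. The two measured steps that place it are (a 1.4-fold lower number from compound 2 to compound 3 (0.14 log units; within the scatter)) and (a 3.5-fold lower number from compound 1 to compound 3 (0.54 log units; beyond the scatter)).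

The next compound is compound 4 `NC(=O)c1c(NC(=O)Nc2ccc(Cl)cc2)sc2c1CCN(C1CCOCC1)C2`, which carries oxan-4-yl in place of cyclobutylmethyl on an amine nitrogen in a ring. Two kinds of measured step bear on this change. Ring-bearing groups gave modest changes against compound 1 (a 2.5-fold lower number from compound 1 to compound 2 (0.40 log units; beyond the scatter)) and (a 3.5-fold lower number from compound 1 to compound 3 (0.54 log units; beyond the scatter)). Exchanging one ring for another moved the number very little (a 1.4-fold lower number from compound 2 to compound 3 (0.14 log units; within the scatter)). Among the compounds with values here, no measured compound carries oxan-4-yl, so this comparison is only a rough guide. In this assay a small step toward a higher number is expected, at most modest in size. For compound 4 the estimated step is (a 1.8-fold higher number from compound 3 to compound 4 (0.25 log units; within the scatter)). Compound 4 is estimated at 2400 nM (expected range 1000 nM to 6000 nM).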

Compound 4, half-maximal effective concentration: 2830 nM
Compound 4: the middle estimate sits 1.2-fold (0.07 log units) below what was measured; measured number inside the range.
By their numbers in this assay, from the lowest: compounds 3, 2, 4 and 1 (each within the scatter of the next, the first and the last beyond it).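

Here (this assay), oxan-4-yl on the amine nitrogen in a ring is the only group among these compounds that contains an oxygen and a hydrogen-bond acceptor, and replacing cyclobutylmethyl with it gives a modest step beyond the usual scatter (a 2.1-fold higher number from compound 3 to compound 4 (0.32 log units; beyond the scatter)). Against cyclohexylmethyl the change stays within the scatter (a 1.5-fold higher number from compound 2 to compound 4 (0.18 log units; within the scatter)), so compound 4 cannot be told apart from compound 2. Against methyl it also stays within the scatter (a 1.7-fold lower number from compound 1 to compound 4 (0.22 log units; within the scatter)), so compound 4 keeps no clear edge over compound 1, whereas compound 2 and compound 3 both do.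

Going by these compounds, how a carboxylic acid, a primary amine or a longer open chain would behave on this nitrogen remains open. Nothing available gives a measured reason for these steps.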